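Hydroxy to methoxy: what to expect of compound 3

This account rests on a few compounds, and the source may have more. Where it says the series, first, only, none or still open, it means among the compounds named here.

Measured in a functional assay on BT-549 cells (Homo sapiens) for antiproliferative activity, read by sulforhodamine B assay, with a stated time of 48 h; a lower number here means a stronger inhibitor of growth, a higher number a weaker inhibitor of growth:
compound 1 `O=C(NCCCNc1cc(-c2cn(-c3ccccc3)nc2-c2cccc(O)c2)ccn1)Nc1ccc(F)cc1`: 11600 nM
compound 2 `O=C(NCCCNc1cc(-c2cn(-c3ccccc3)nc2-c2cccc(O)c2)ccn1)Nc1cccc(C(F)(F)F)c1`: 7630 nM

For the measured compounds named here, only two compounds have numbers so far, and the first has no clear place above or below the other: a 1.5-fold lower number from compound 1 to compound 2 (0.18 log units; within the scatter). Compound 3 `COc1cccc(-c2nn(-c3ccccc3)cc2-c2ccnc(NCCCNC(=O)Nc3ccc(F)cc3)c2)c1` keeps the rest of compound 1 and alters one group: methyl in place of hydrogen on an oxygen on an aromatic ring. In words, this is methyl in place of hydrogen on an oxygen on an aromatic ring, or 3-hydroxyphenyl to 3-methoxyphenyl. Going by the values given here, no measured pair shows a change at this oxygen. Among the compounds with values here, the single measured step, a 1.5-fold lower number from compound 1 to compound 2 (0.18 log units; within the scatter), concerns a different group, on an amide-type nitrogen, so it bears on this change only loosely. No step beyond the scatter is therefore expected in this assay, in either direction. The expected step is a 1.2-fold lower number from compound 1 to compound 3 (0.06 log units; within the scatter). For compound 3 the estimate is 10000 nM, with an expected range of 4000 nM to 25000 nM.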

Compound 3, concentration for total growth inhibition: 20300 nM
The estimate for compound 3 lay 2.0-fold (0.31 log units) below the measured number; low and high end bracket the measured number.
By their numbers in this assay, from the lowest: compounds 2, 1 and 3 (each within the scatter of the next, the first and the last beyond it).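

For the compounds shown here, the measure is this assay and the change from 3-hydroxyphenyl to 3-methoxyphenyl gives a 1.8-fold higher number from compound 1 to compound 3 (0.24 log units; within the scatter) as the first reading at this oxygen. Placing a methyl on the oxygen therefore leaves the number within the usual scatter, so this single pair gives no sign that the hydrogen on this oxygen matters for this read-out. Nothing measured here explains this result.

As far as these compounds go, whether an ethyl on this oxygen, or an amine or a fluorine in place of the hydroxy group, would move the number beyond the scatter stays open. Also open, from the compounds shown here alone, is whether the same methyl on compound 2, which carries the 3-(trifluoromethyl)phenyl group, would give a step of similar size.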